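The compounds below may be only part of what the source reports. "The series", "measured", "known", "first", "only" and "open" are said of these compounds alone.

Measured so far in a functional assay on NUGC-3 cells (Homo sapiens) for inhibition, read by sulforhodamine B assay; a higher number here means a weaker inhibitor of growth, a lower number a stronger inhibitor of growth:
compound 1, `O=C(CCC1=CCN(CCCc2ccc(Cl)cc2)C1=O)NO`: 2200 nM
compound 2, `O=C(CCC1=CCN(CCCCc2ccc(Cl)cc2)C1=O)NO`: 3530 nM
compound 3, `CC(C)(C)c1ccc(CN2CC=C(CCC(=O)NO)C2=O)cc1`: 720 nM

In this assay compound 1 gives 2200 nM, the second highest of the three numbers. Compound 2 gives 3530 nM, within the scatter of compound 1, so the two cannot be told apart. Compound 3 gives 720 nM, which is beyond the scatter and lower than compound 1; compound 3 differs from compound 1 in more than one place, so no single step can be read from that pair.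

Compound 4 is `Cc1ccc(CCCN2CC=C(CCC(=O)NO)C2=O)cc1`. It differs from compound 1 in one place: methyl in place of chloro on an aromatic carbon. Going by the values given here, no pair of measured compounds shows this change, so its effect in this assay has to be guessed from the structures alone. The chloro and methyl groups are each one heavy atom, bring no ring, no donor and no acceptor, and sit on the same aromatic carbon, so a small step in either direction, none beyond the scatter, is expected.

The number for compound 4 is estimated at 2500 nM, with a range from 1100 nM to 5500 nM. The expected step of a 1.1-fold higher number from compound 1 to compound 4 (0.06 log units; within the scatter) is small and within the scatter.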

Compound 4, concentration for 50% growth inhibition: 2200 nM
Compound 4: the middle estimate sits 1.1-fold (0.06 log units) above what was measured; low and high end bracket the measured number.
By their numbers in this assay, from the lowest: compound 3; then compounds 1, 4 and 2 (each within the scatter of the next).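

Working note: in this assay, methyl in place of chloro on this aromatic carbon gives no change at the digits printed from compound 1 to compound 4 (within the scatter), the first step in the series that can be read at a single place. At this position, para to a large group, 4-methylphenyl therefore reads the same as 4-chlorophenyl on the core of compound 1, so chloro is not needed to keep the growth inhibition seen in this pair. No measurement shown here bears on why the two groups read alike.

Still open, from the compounds shown here alone, is how this position responds to groups of another kind, such as methoxy, an amine or a carboxylic acid, or to plain hydrogen. Also open, going by these compounds, is whether methyl in place of chloro reads the same on the longer chain of compound 2.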